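From a fluorobenzyl thioether to a hydroxymethoxyphenyl ketone

This account rests on a few compounds, and the source may have more. Where it says the series, first, only, none or still open, it means among the compounds named here.

Measured so far in a functional assay on HepG2 cells (Homo sapiens) for inhibition, read by MTT assay, with a stated time of 48 h; a higher number here means a weaker inhibitor, a lower number a stronger inhibitor:
Compound 1 `COc1cc(-c2nnc(SCc3ccc(C)cc3)n2-c2ccc(N(C)C)cc2)cc(OC)c1OC` gives > 60000 nM as a limit
Compound 2 `COc1cc(-c2nnc(SCc3ccc(F)cc3)n2-c2ccc(N(C)C)cc2)cc(OC)c1OC` gives 26400 nM as a number

Among the compounds with values here, compound 2 at 26400 nM holds the only actual number so far. Compound 3 `COc1ccc(C(=O)CSc2nnc(-c3cc(OC)c(OC)c(OC)c3)n2-c2ccc(N(C)C)cc2)cc1O` differs from compound 2 by (3-hydroxy-4-methoxyphenyl)carbonyl in place of 4-fluorophenyl on a saturated chain carbon bound to a sulfur and has not been measured. Within the data shown here, the only measured step is an at least 2.2-fold lower number from compound 1 to compound 2 (0.35 log units; beyond the scatter) and it changes the same aromatic ring that leaves here. That step supports a direction only weakly, and its end at compound 1 is a limit. A lower number is expected in this assay with an estimated 8.8-fold lower number from compound 2 to compound 3 (0.94 log units; beyond the scatter) as the result. Compound 3 is estimated at 3000 nM with an expected range from 100 nM to 40000 nM here.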

Compound 3, half-maximal inhibitory concentration: > 100000 nM
Compound 3 gave a limit, no number; the forecaster's own chance of this, stated with the estimate: 10%; middle value at least 33-fold (1.52 log units) from the limit.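

At the saturated chain carbon bound to a sulfur, (3-hydroxy-4-methoxyphenyl)carbonyl in place of 4-fluorophenyl gives, in this assay, an at least 3.7-fold higher number from compound 2 to compound 3 (0.57 log units; beyond the scatter), so this change moves the number upward, unlike the fluoro step. Compound 3 gives a limit and not a number: the limit of > 100000 nM in this assay, at which 1 of the 3 values shown sits. The step between compound 1 and compound 3 cannot be read, as both ends are limits. The compounds shown leave open whether the carbonyl or the hydroxy and methoxy groups go with the higher number. Going by these compounds, how an amine or a carboxylic acid on this chain would read also remains open.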